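The compounds below may be only part of what the source reports. "The series", "measured", "known", "first", "only" and "open" are said of these compounds alone.

Measured compounds in a functional assay on cells for positive allosteric modulation of G-protein coupled receptor 68 (Homo sapiens), read by a luciferase reporter and cAMP accumulation, with a stated time of 30 min, at pH 6.8 and pH 8.3, in the presence of a further agent that is not named here; on this read-out lower numbers stand for lower potency and higher numbers for higher potency (the scale is a negative logarithm):
compound 1 `Nc1nc(NCc2ccccc2)nc(-c2ccccc2CO)n1`, 4.35
compound 2 `Nc1nc(NCc2ccc(Oc3ccccc3)cc2)nc(-c2ccccc2CO)n1`, 5.19
compound 3 `Nc1nc(NCCCCc2ccccc2)nc(-c2ccccc2CO)n1`, 5.52

Compound 1 and compound 2 share the same core and differ only by phenoxy in place of hydrogen on an aromatic carbon. That single change gives a number 0.84 log units higher from compound 1 to compound 2 (beyond the scatter).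

Compound 3 has a different core from compound 1; how the two cores differ is not broken down here. Among the three measured values in this assay compound 3 stands highest, with compound 2 nearest and compound 1 furthest, and both of those gaps lie beyond the scatter of repeated measurements.

Compound 4 `Nc1nc(NCCCCc2ccc(Oc3ccccc3)cc2)nc(-c2ccccc2CO)n1` has not yet been measured. It differs from compound 3 by phenoxy in place of hydrogen on an aromatic carbon. The place is described in the same words as for the change from compound 1 to compound 2, so this is the same change, made here on the core of compound 3; among the compounds shown it occurs twice in all. Among the measured compounds shown here, the only measured instance of it is the step from compound 1 to compound 2, which was a number 0.84 log units higher from compound 1 to compound 2 (beyond the scatter) on the other core. A step of about that size is expected for compound 4 in this assay, and the expected step is a number 0.68 log units higher from compound 3 to compound 4 (beyond the scatter), which rests on that one earlier instance alone. Compound 4 is therefore estimated at 6.2, with a range from 5.7 to 6.7.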

Compound 4, negative logarithm of the antagonist equilibrium constant: 4.81
Estimate against measurement, compound 4: 1.39 log units above, outside the stated range (below it).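

In this assay, phenoxy in place of hydrogen on an aromatic carbon, para to a large group, gives a number 0.71 log units lower from compound 3 to compound 4 (beyond the scatter), so the step does not keep its direction from one core to the other: the same change on two cores in this assay, a number 0.84 log units higher (beyond the scatter) from compound 1 to compound 2 and a number 0.71 log units lower (beyond the scatter) from compound 3 to compound 4, 1.55 log units apart, beyond the scatter of two such steps. The step measured on the core of compound 1 therefore cannot be carried over as a fixed increment to the core of compound 3, and in this series the effect of this change has to be read core by core. Among the compounds shown here, with only one instance on each core, this shows that the outcome depends on the core but not which feature of the core is responsible, nor how the change would behave on any further core.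

The compounds shown carry only hydrogen or phenoxy at this place, so it remains open whether a smaller group such as methoxy, or a carboxylic acid, would also split in direction on the two cores. On these data alone, it also remains open how the step would run on a core with a chain of another length, such as a longer chain, carrying the same phenoxy group.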